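The source may report more compounds than this note shows. Statements on the series, on what has been measured and on what is new or still open speak of the compounds shown alone.

Of the compounds shown here, two have been measured so far in a functional assay on K562 cells (Homo sapiens) for cytotoxicity, read by ELISA, with a stated time of 4 days; on this read-out higher numbers stand for weaker inhibition and lower numbers for stronger inhibition. There, compound 1 `Clc1ccc(-c2cc(-c3ccco3)cc(-c3ccc(Cl)s3)n2)cc1` gives 10500 nM and compound 2 `Cc1ccc(-c2cc(-c3ccoc3)cc(-c3ccc(Cl)s3)n2)o1` gives 12700 nM. For the measured compounds named here, these two values lie within the scatter of each other, so compound 2 stands level with the only other measured compound. Compound 3 `Clc1ccc(-c2cc(-c3ccoc3)cc(-c3ccccc3Cl)n2)s1` keeps the furan-3-yl and 5-chlorothiophen-2-yl groups of compound 2. It carries 2-chlorophenyl in place of 5-methylfuran-2-yl on an aromatic carbon of a six-membered aromatic ring with 1 nitrogen, next to the ring nitrogen: 2-chlorophenyl in place of 5-methylfuran-2-yl on an aromatic carbon. Going by the values given here, no two measured compounds differ in one place only, so no measured step speaks directly to this change. Among the compounds with values here, the one measured compound with a chlorophenyl group is compound 1, at 10500 nM, which is within the scatter of compound 2. On that basis, no step beyond the scatter is expected in this assay, and neither direction is clearly favoured. The expected change is a 1.3-fold lower number from compound 2 to compound 3 (0.10 log units; within the scatter), which would stay within the scatter. For compound 3 the estimated value is 10000 nM, with an expected range from 4000 nM to 28000 nM.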

Compound 3, half-maximal inhibitory concentration: 15800 nM
Compound 3: middle estimate off by 1.6-fold (0.20 log units), on the low side; the range from low to high includes it.
By their numbers in this assay, from the lowest: compounds 1, 2 and 3 (each within the scatter of the next).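

For the compounds shown here, the pair of compound 2 and compound 3 gives the first reading of a change in one place only: in this assay, putting 2-chlorophenyl in place of 5-methylfuran-2-yl on an aromatic carbon, next to the ring nitrogen, gives a 1.2-fold higher number from compound 2 to compound 3 (0.09 log units; within the scatter). At this position, a five-membered aromatic ring with 1 hetero atom and a six-membered aromatic ring of carbon only thus stand level, and the loss of the hydrogen-bond acceptor counted on the leaving group, along with the added chlorine, does not separate the two compounds. The data shown offer no independent measurement that could explain this result.

With only these two groups compared here, the compounds shown leave open whether the position responds to any other kind of substituent, such as an amine like morpholine, a carboxylic acid or a longer alkyl chain. They also leave open whether any change at this position, or at the furan-3-yl and 5-chlorothiophen-2-yl groups, can move the number beyond the scatter.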